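This account rests on a few compounds, and the source may have more. Where it says the series, first, only, none or still open, it means among the compounds named here.

Measured compounds in an ADME assay on L02 cells (Homo sapiens) for antiproliferative activity, read by MTT assay, with a stated time of 48 h; on this read-out lower numbers stand for stronger inhibition and higher numbers for weaker inhibition:

compound 1, `CCOc1ccc(-n2nncc2CN2C(=O)C3(C(C#N)=C(N)Oc4c3c3nc5ccccc5nc3c3ccccc43)c3ccccc32)cc1`: compound 1 gives > 50000 nM, a limit of the assay.
compound 2, `N#CC1=C(N)Oc2c(c3nc4ccccc4nc3c3ccccc23)C12C(=O)N(Cc1cnnn1-c1ccc(N)cc1)c1ccccc12`: compound 2 gives > 50000 nM, a limit of the assay.
compound 3, `N#CC1=C(N)Oc2c(N)cc3nc4ccccc4nc3c2C12C(=O)N(Cc1cnnn1-c1ccccc1Br)c1ccccc12`: compound 3 gives 29200 nM.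

Among the measured compounds shown here, compound 3 is the only compound with a number; the other two values are limits, as the limit of > 50000 nM in this assay, at which 2 of the 3 values shown sit, shows. For the measured compounds named here, the one step between measured compounds, a step that the two limits leave unreadable from compound 1 to compound 2, cannot be sized, as both of its values are limits.

Compound 4, `COc1ccc(OC)c(-n2nncc2CN2C(=O)C3(C(C#N)=C(N)Oc4c(N)cc5nc6ccccc6nc5c43)c3ccccc32)c1`, differs from compound 3 in 2,5-dimethoxyphenyl in place of 2-bromophenyl on an aromatic nitrogen. Going by the values given here, no measured step bears on this position, and the only measured step cannot be read, so no direction can be taken from the series itself. With no evidence for a change, the expectation for a 1.4-fold higher number from compound 3 to compound 4 (0.14 log units; within the scatter) is a step within the scatter. Compound 4 is therefore estimated at 40000 nM, with a range from 15000 nM to 90000 nM. Since two of the three values shown sit at the limit of > 50000 nM in this assay, at which 2 of the 3 values shown sit, a limit rather than a number is a real possibility for compound 4 as well.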

Compound 4, half-maximal inhibitory concentration: > 50000 nM
Compound 4: a limit, no number; the forecaster's own chance of this, stated with the estimate: 45%; middle value at least 1.2-fold (0.09 log units) from the limit.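

In this assay compound 4 gives > 50000 nM, which is a limit and not a number. From the compounds shown here alone, at the group on the aromatic nitrogen, 2,5-dimethoxyphenyl in place of 2-bromophenyl gives an at least 1.7-fold higher number from compound 3 to compound 4 (0.23 log units; that floor lies within the scatter), so this change brings no gain in inhibition, and its true size stays open above a floor that lies within the scatter. Among the compounds shown here, compound 3 remains the only compound with a number, and the limit now holds most of the series: the limit of > 50000 nM in this assay, at which 3 of the 4 values shown sit.

Going by these compounds, whether a plain phenyl, a pyridine ring or a short alkyl chain on that nitrogen would give a number rather than a limit stays open. With a single number in the series, no ranking of groups at this position can yet be read.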